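Chain length between the core and the phenoxy group

The source may hold more compounds than are shown below. What is called first, only, known or untested is meant among the compounds shown, and "the series" means these compounds.

Three compounds of the series have numbers in a functional assay on CHO cells for agonist activity at prostaglandin E2 receptor EP2 subtype (Homo sapiens), read by HTRF and cAMP accumulation, with a stated time of 30 min; on this read-out lower numbers stand for an effect already at smaller amounts and higher numbers for an effect only at larger amounts of compound. Compound 1 `O=C(O)c1csc([C@H]2CC[C@@H]3[C@@H](/C=C/COc4ccccc4)[C@H](O)C[C@@H]3O2)n1` gives 3.8 nM; compound 2 `O=C(O)c1csc([C@H]2CC[C@@H]3[C@@H](/C=C/CCCOc4ccccc4)[C@H](O)C[C@@H]3O2)n1` gives 13 nM; compound 3 `O=C(O)c1csc([C@H]2CC[C@@H]3[C@@H](COc4ccc(F)cc4)[C@H](O)C[C@@H]3O2)n1` gives 7 nM. Compound 2 has the highest number of the three, and its gap to compound 3 lies within the scatter, so no order between those two can be read; against compound 1 the step of a 3.4-fold higher number from compound 1 to compound 2 (0.53 log units; beyond the scatter) lies beyond the scatter.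

Compound 4 `O=C(O)c1csc([C@H]2CC[C@@H]3[C@@H](/C=C/CCOc4ccccc4)[C@H](O)C[C@@H]3O2)n1` carries phenoxy in place of phenoxymethyl on a saturated chain carbon, two bonds along the chain from a double-bonded chain carbon. The same difference, cut one bond further out, reads 2-phenoxyethyl to phenoxymethyl and 3-phenoxypropyl to 2-phenoxyethyl, so compound 4 sits between compound 1 and compound 2 on this chain. Among the compounds with values here, only the step from compound 1 to compound 2 bears on it, and it was modest in the unfavourable direction. Shortening the chain back by one carbon is therefore expected to recover part of that step. A step of a 1.9-fold lower number from compound 2 to compound 4 (0.27 log units; within the scatter) is expected. Compound 4 is estimated at 7 nM, with a range from 3 nM to 18 nM.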

Compound 4, half-maximal effective concentration: 3.9 nM
Compound 4: the middle estimate sits 1.8-fold (0.25 log units) above what was measured, within the range that was stated.
By their numbers in this assay, from the lowest: compounds 1, 4, 3 and 2 (each within the scatter of the next, the first and the last beyond it).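

In this assay the change on this chain does not build evenly with length: the step of a 3.3-fold lower number from compound 2 to compound 4 (0.52 log units; beyond the scatter) lies beyond the scatter, whereas the step of a 1.0-fold higher number from compound 1 to compound 4 (0.01 log units; within the scatter) lies within it. The chain of compound 4 therefore gives no number that can be told apart from that of compound 1, and the rise seen on going out to compound 2 appears only with the last added carbon. Nothing on hand gives a reason for this break along the chain.

As far as these compounds go, whether an amine in place of the ether oxygen, or a pyridine ring in place of the benzene ring of the phenoxy group, would hold the number of compound 4 remains open. So does whether a fully saturated chain of the same length would behave like the chain with the double bond.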